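Fluorine on the pendant phenyl ring of two amide cores

The source may report more compounds than this note shows. Statements on the series, on what has been measured and on what is new or still open speak of the compounds shown alone.

Three compounds were tested in a functional assay on HT-29 cells (Homo sapiens) for cytotoxicity, read by MTT assay, with a stated time of 72 h; on this read-out lower numbers stand for stronger inhibition and higher numbers for weaker inhibition. Compound 1 `O=C(Nc1ccc(Oc2ccncc2-c2cccnc2)c(F)c1)c1nn(-c2cccc(F)c2)c(=O)c2ccccc12` gives 410 nM, and compound 2 `O=C(Nc1ccc(Oc2ccncc2-c2cccnc2)c(F)c1)c1nn(-c2ccccc2)c(=O)c2ccccc12` gives 1240 nM. The change from compound 2 to compound 1 is fluoro in place of hydrogen on an aromatic carbon, and it made a step of a 3.0-fold lower number from compound 2 to compound 1 (0.48 log units; beyond the scatter). Compound 3 `Cn1cc(-c2ccccc2)cc(C(=O)Nc2ccc(Oc3ccncc3-c3cccnc3)c(F)c2)c1=O`, built on a different core, gives 7420 nM in this assay; the difference between the two cores is not broken down here. Compound 4 `Cn1cc(-c2ccc(F)cc2)cc(C(=O)Nc2ccc(Oc3ccncc3-c3cccnc3)c(F)c2)c1=O` has not yet been measured. It differs from compound 3 by fluoro in place of hydrogen on an aromatic carbon, the same kind of change as that from compound 2 to compound 1, though the fluorine there sits meta to a large group and here para to a large group. Because the earlier step was a 3.0-fold lower number from compound 2 to compound 1 (0.48 log units; beyond the scatter), a smaller gain is expected for compound 4, namely a 2.1-fold lower number from compound 3 to compound 4 (0.33 log units; beyond the scatter). Compound 4 is therefore estimated at 3500 nM in this assay, between 1500 nM and 9000 nM.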

Compound 4, half-maximal inhibitory concentration: 11200 nM
For compound 4 the middle estimate is 3.2-fold (0.51 log units) below the measured one; measured number above the stated range.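

Fluoro in place of hydrogen did not carry over from one core to the other in this assay: the same change on two cores in this assay, a 3.0-fold lower number (0.48 log units; beyond the scatter) from compound 2 to compound 1 and a 1.5-fold higher number (0.18 log units; within the scatter) from compound 3 to compound 4, 4.6-fold (0.66 log units) apart, beyond the scatter of two such steps. On the core of compound 3, the change from phenyl to 4-fluorophenyl gave a 1.5-fold higher number from compound 3 to compound 4 (0.18 log units; within the scatter), and no effect of the fluorine can be told apart there. This does not show that the core alone decides the outcome, since the fluorine also sits at a different place on the phenyl ring in the two pairs, and one pair per core sets no rule for the series.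

The compounds shown leave open how the two cores would compare with the fluorine at the same place on the ring. They also leave open whether chloro, methyl or methoxy in place of that hydrogen would differ between the cores.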